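The compounds below may be only part of what the source reports. "The series", "measured", "known", "first", "only" and "open" are said of these compounds alone.

Compound 1 `COc1cccc(/C=C/C(=O)c2ccccc2O)c1` gives 89.6% in a functional assay on HCT-116 cells (Homo sapiens) for cytotoxicity, read by MTT assay, with a stated time of 48 h, tested at 15 uM; on this read-out lower numbers stand for a stronger effect and higher numbers for a weaker effect at the one concentration tested.
Compound 2 `O=C(/C=C/c1ccc(Br)cc1)c1ccccc1O` gives 68.4% in this assay.

Of these two numbers compound 2 stands lowest, and compound 1 lies higher by a gap beyond the usual scatter. Compound 3 `O=C(/C=C/c1ccc(C(F)(F)F)cc1)c1ccccc1O` differs from compound 2 in one place: trifluoromethyl in place of bromo on an aromatic carbon. For the measured compounds named here, no measured pair shows what this kind of exchange does here, so the expectation rests on compound 2 alone, and the step from bromo to trifluoromethyl is expected to be small, a number 1.6 percentage points higher from compound 2 to compound 3 (within the scatter), not clearly beyond the scatter in either direction. For compound 3 the estimate in this assay is 70%, with a range from 52% to 88%.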

Compound 3, a percentage reported as activity, at one concentration (the size of the read-out at that concentration, not a potency): 85.1%
Estimate against measurement, compound 3: 15.1 percentage points below; measured number inside the range.
By their numbers in this assay, from the lowest: compound 2; then compounds 3 and 1 (each within the scatter of the next).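

At this position, on an aromatic carbon para to a large group, the exchange is not neutral: in this assay trifluoromethyl in place of bromo gives a number 16.7 percentage points higher from compound 2 to compound 3 (beyond the scatter) and so a weaker effect at the one concentration tested. Bromo and trifluoromethyl are therefore not interchangeable here, and of this pair bromo is the better group. No measurement at hand accounts for the step.

From the compounds shown here alone, whether any other group on this carbon, such as an amine or a carboxylic acid, would give a lower number than bromo remains open.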